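The source may hold more compounds than are shown below. What is called first, only, known or untested is meant among the compounds shown, and "the series" means these compounds.

In an ADME assay on L02 cells (Homo sapiens) for cytotoxicity, read by MTT assay (a higher number here means a weaker inhibitor, a lower number a stronger inhibitor), compound 1 `COc1ccc(/C=C/C(=O)c2ccc(OC)c3c2OC(C)(C)C=C3)cc1OCCCN(C)C` gives 8600 nM. Compound 2 `CCC(=O)Oc1cc(/C=C/C(=O)c2ccc(OC)c3c2OC(C)(C)C=C3)ccc1OC` reads > 10000 nM, which is a limit of the assay and not a number. Compound 2 therefore has no exact position on the scale, only that limit.

Compound 3 `COc1ccc(/C=C/C(=O)c2ccc(OC)c3c2OC(C)(C)C=C3)cc1OC(=O)CCl` differs from compound 2 by a single swap, chloro in place of methyl on a saturated chain carbon bound to a carbonyl carbon, which turns propanoyl to (chloromethyl)carbonyl.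

Going by the values given here, the only measured step is an at least 1.1-fold higher number from compound 1 to compound 2 (0.06 log units; that floor lies within the scatter). It involves a different exchange and gives only a floor, so it sets no size for this smaller swap. No step beyond the scatter is therefore expected in this assay, and no direction can be named. The expected step is an at least 1.1-fold lower number from compound 2 to compound 3 (0.04 log units; that floor lies within the scatter). Compound 3 is expected at about 9000 nM, with an estimated range from 4000 nM to 20000 nM.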

Compound 3, half-maximal inhibitory concentration: > 10000 nM
Compound 3: only a limit was reported; the forecaster's own chance of this, stated with the estimate: 50%; middle value at least 1.1-fold (0.04 log units) away from the limit.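

In this assay, compound 3 gives > 10000 nM, which is a limit of the assay and not a number. Compound 2 and compound 3 therefore both sit at the limit, and the step for chloro in place of methyl on this saturated chain carbon cannot be read because neither compound has an exact value: the limit of > 10000 nM in this assay, at which 2 of the 3 values shown sit. Putting (chloromethyl)carbonyl in place of 3-(dimethylamino)propyl on an oxygen on an aromatic ring gives an at least 1.1-fold higher number from compound 1 to compound 3 (0.06 log units; that floor lies within the scatter), so this second exchange also shows no step beyond the scatter.

Where compound 2 and compound 3 truly lie on the scale stays open, as does whether chloro in place of methyl changes the reading at all. An amine or a longer chain on the same saturated chain carbon could show whether any group there gives a reading with an exact value.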